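The compounds below may be only part of what the source reports. "The series", "measured", "known", "first", "only" and "open" are said of these compounds alone.

Compound 1, `NC(=O)CCCN(Cc1cccc(C(=O)O)c1)C[C@H]1O[C@@H](n2cnc3c(N)ncnc32)[C@H](O)[C@@H]1O`, was tested in an assay on cells for inhibition of Nicotinamide N-methyltransferase (Homo sapiens), with stated times of 10 min and 30 min; a higher number here means a weaker inhibitor, a lower number a stronger inhibitor. In this assay compound 1 gives only a limit, > 250000 nM, not a number. Compound 2, `Nc1ncnc2c1ncn2[C@@H]1O[C@H](CN(CCCC(=O)O)Cc2cccc(C(=O)O)c2)[C@@H](O)[C@H]1O`, differs from compound 1 in having hydroxy in place of amino on a carbonyl carbon. In this assay compound 2 likewise gives only a limit, > 250000 nM. The step from compound 1 to compound 2 is therefore a step that the two limits leave unreadable from compound 1 to compound 2, and compound 2 stands at the limit of > 250000 nM in this assay, at which 2 of the 2 values shown sit, with no number of its own. Compound 3, `Nc1ncnc2c1ncn2[C@@H]1O[C@H](CN(CCCCC(=O)O)Cc2cccc(C(=O)O)c2)[C@@H](O)[C@H]1O`, carries carboxymethyl in place of carboxy on a saturated chain carbon, three bonds along the chain from an amine nitrogen. Among the measured compounds shown here, the one measured step offers no size to build on, so no direction can be read for the change from compound 2 to compound 3. Compound 3 is expected to give a result near the same limit, estimated at 300000 nM, between 100000 nM and 1000000 nM. The step from compound 2 to compound 3 is thus estimated as a step that the limit leaves unreadable from compound 2 to compound 3.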

Compound 3, half-maximal inhibitory concentration: > 250000 nM
Compound 3: a limit, no number; the forecaster's own chance of this, stated with the estimate: 85%; the middle value does not contradict the limit.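

In this assay compound 3 gives only a limit, > 250000 nM, not a number. No step among compound 1, compound 2 and compound 3 can therefore be read: the limit of > 250000 nM in this assay, at which 3 of the 3 values shown sit.

Whether carbamoyl, carboxy or carboxymethyl at this place makes any difference to inhibition stays open, as none of these compounds gives a number.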